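Cyclobutyl to cyclopentyl on two quinoxaline di-N-oxide cores

The source may report more compounds than this note shows. Statements on the series, on what has been measured and on what is new or still open speak of the compounds shown alone.

Three compounds in the series have numbers from an ADME assay on Vero cells (Chlorocebus sabaeus) for cytotoxicity, read by CellTiter-Glo, with a stated time of 72 h; a higher number here means that more compound is tolerated, a lower number that less compound is tolerated. Compound 1 `[O-][n+]1nc(NC2CCC2)[n+]([O-])c2ccc(Br)cc21` gives 3.8 ug/mL. Compound 2 `[O-][n+]1nc(NC2CCCC2)[n+]([O-])c2ccc(Br)cc21` gives 18 ug/mL. Compound 3 `Cc1cccc2c1[n+]([O-])c(NC1CCC1)n[n+]2[O-]` gives 22 ug/mL. Compound 4 `Cc1cccc2c1[n+]([O-])c(NC1CCCC1)n[n+]2[O-]` has not yet been measured in this assay.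

The difference between compound 1 and compound 2 is cyclopentyl in place of cyclobutyl on a nitrogen on an aromatic ring. In this assay this step reads a 4.7-fold higher number from compound 1 to compound 2 (0.68 log units; beyond the scatter). Compound 3 carries the highest number of the three, but its gap to compound 2 lies within the scatter, while its gap to compound 1 lies beyond it.

Compound 4 stands to compound 3 as compound 2 stands to compound 1: the difference is cyclopentyl in place of cyclobutyl on a nitrogen on an aromatic ring. The two place descriptions agree word for word, so this is the same change made on a different core. How the core of compound 3 differs from the core of compound 1 is not broken down here.

The expectation for compound 4 rests on one pairing only. Because the step of a 4.7-fold higher number from compound 1 to compound 2 (0.68 log units; beyond the scatter) was modest and beyond the scatter, the step from compound 3 to compound 4 is expected to be of a similar kind, a 2.7-fold higher number from compound 3 to compound 4 (0.44 log units; beyond the scatter). Compound 4 is therefore estimated at 60 ug/mL in this assay, with a range from 25 ug/mL to 150 ug/mL. For the measured compounds named here, the single precedent makes this estimate uncertain; a number near that of compound 3 cannot be ruled out.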

Compound 4, half-maximal cytotoxic concentration: 3.7 ug/mL
For compound 4 the middle estimate is 16-fold (1.21 log units) above the measured one; measured number below the stated range.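

In this assay, cyclopentyl in place of cyclobutyl on a nitrogen on an aromatic ring does not carry over from one core to the other: on the core of compound 3 the change gives a 5.9-fold lower number from compound 3 to compound 4 (0.77 log units; beyond the scatter). This shows that, among these four compounds, a step read on the core of compound 1 cannot be used to predict either the size or the direction of the step on the core of compound 3, whereas it does not show which feature of the two cores lies behind the reversal, and with one pair on each core it supports no general rule for the series. The two steps run in opposite directions, and the gap between them is larger than the scatter can account for: the same change on two cores in this assay, a 4.7-fold higher number (0.68 log units; beyond the scatter) from compound 1 to compound 2 and a 5.9-fold lower number (0.77 log units; beyond the scatter) from compound 3 to compound 4, 28-fold (1.45 log units) apart, beyond the scatter of two such steps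

The compounds shown leave open whether the reversal extends to other groups on the same nitrogen, such as cyclopropyl, cyclohexyl or a longer open chain like butyl, or whether it is confined to this one pair of rings. They also leave open how the same change behaves on a third core, for example one carrying chlorine or a methoxy group, which would show whether either of the two steps is the more typical.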